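The compounds below may be only part of what the source reports. "The series", "measured", "known", "first", "only" and "open" are said of these compounds alone.

Within the data shown here, compound 1 `Cc1cc(S(=O)(=O)/N=C(\N)N/N=C/C#Cc2ccccc2)c(SCc2ccccc2C)cc1Cl` gives 19000 nM in a functional assay on HCT-116 cells (Homo sapiens) for antiproliferative activity, read by MTT assay, with a stated time of 72 h (on this read-out higher numbers stand for weaker inhibition and lower numbers for stronger inhibition), while compound 2 `C/C(C#Cc1ccccc1)=N\N/C(N)=N/S(=O)(=O)c1cc(C)c(Cl)cc1SCc1ccccc1C` gives 142000 nM in this assay, the higher of the two numbers measured, and the one measured step is a 7.5-fold higher number from compound 1 to compound 2 (0.87 log units; beyond the scatter). Compound 3 `C/C(C#Cc1ccccc1)=N\N/C(N)=N/S(=O)(=O)c1cc(C)c(Cl)cc1SCc1ccc(C)cc1` differs from compound 2 by 4-methylphenyl in place of 2-methylphenyl on a saturated chain carbon bound to a sulfur. Among the measured compounds shown here, no measured step touches this part of the molecule, since the only step measured alters the group on the amine nitrogen rather than the saturated chain carbon bound to a sulfur. Compound 3 is therefore expected to show a 1.0-fold lower number from compound 2 to compound 3 (0.01 log units; within the scatter), nothing beyond the scatter. The estimated value for compound 3 is 140000 nM, within a range from 50000 nM to 400000 nM.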

Compound 3, half-maximal inhibitory concentration: 13000 nM
The estimate for compound 3 lay 11-fold (1.03 log units) above the measured number; the whole stated range lies above it.
By their numbers in this assay, from the lowest: compounds 3 and 1 (each within the scatter of the next); then compound 2.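

Changing only where the methyl sits, with 4-methylphenyl in place of 2-methylphenyl on a saturated chain carbon bound to a sulfur, gives an 11-fold lower number from compound 2 to compound 3 (1.04 log units; beyond the scatter) in this assay and shows that this position responds beyond the scatter. The earlier compounds had shown a change only on the amine nitrogen; here the two groups have the same atoms, joined differently. Nothing at hand accounts for the difference. From the compounds shown here alone, whether the change reads the same on the core of compound 1 remains open, as does how a 4-chlorophenyl or a plain phenyl would behave at this place.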